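Cytotoxicity notes on a semicarbazone series

A few compounds are considered here, and "the series" means these few. Any claim that something is new, unique, unknown or untested is made for them only; others in the source may bear on it.

Measured compounds:
compound 1, `CN(C)CCn1cnnc1-c1cc(Oc2ccc(NC(=O)N/N=C/c3ccc(F)cc3)cc2F)ccn1`, an ADME assay on WI-38 cells (Homo sapiens) for cytotoxicity, read by MTT assay, with a stated time of 72 h; a higher number here means a weaker inhibitor, a lower number a stronger inhibitor: 3980 nM
compound 2, `CN(C)CCn1cnnc1-c1cc(Oc2ccc(NC(=O)N/N=C/c3ccc(O)c(F)c3)cc2F)ccn1`, this assay: "not determined" (no result reported)

For the measured compounds named here, compound 1 is the only member of the series with a number in this assay, where compound 1 gives 3980 nM. Compound 2 shares the core of compound 1 and differs in the aryl group on the carbon with a double bond to nitrogen, but for compound 2 no number exists in this assay, so compound 2 stands nowhere on the scale shown; it offers no anchor of its own.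

Compound 3 is `Cc1cc(/C=N/NC(=O)Nc2ccc(Oc3ccnc(-c4nncn4CCN(C)C)c3)c(F)c2)cc(C)c1O`. It differs from compound 2 in one place: 4-hydroxy-3,5-dimethylphenyl in place of 3-fluoro-4-hydroxyphenyl on a carbon with a double bond to nitrogen. Going by the values given here, no step between measured compounds is available, so the size of this step cannot be read from the series. With compound 2 undetermined, the expectation for compound 3 can rest only on compound 1, which gives 3980 nM in this assay, and on the absence of any measured step in this assay; nothing beyond the scatter is assumed in either direction.

Compound 3 is expected to give about 4000 nM in this assay, in a range from 1500 nM to 12000 nM.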

Compound 3, half-maximal inhibitory concentration: 3610 nM
For compound 3 the middle estimate is 1.1-fold (0.04 log units) above the measured one; the range from low to high includes it.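

In this assay, for the compounds shown here, the exchange of 4-fluorophenyl for 4-hydroxy-3,5-dimethylphenyl on a carbon with a double bond to nitrogen gives a 1.1-fold lower number from compound 1 to compound 3 (0.04 log units; within the scatter) and is the first readable step at this position. The read-out therefore does not separate these two aryl groups, although one carries a hydroxy group and two methyl groups and the other a fluorine, so this position now has one pair showing that such a change can leave the number within the scatter. The step from compound 2 to compound 3 cannot be read, since compound 2 has no number, and nothing at hand accounts for the two aryl groups reading alike.

Still open, as far as these compounds go, is whether this holds for any aryl group at this position, for instance one carrying an amine or a carboxylic acid, or for a longer chain in place of the ring. One pair also leaves open whether the 3-fluoro-4-hydroxyphenyl group of compound 2 would read with the other two, and whether any group at this position moves the number beyond the scatter.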